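This account rests on a few compounds, and the source may have more. Where it says the series, first, only, none or still open, it means among the compounds named here.

Measured in an ADME assay on a cell-free system (plasma, Homo sapiens) for metabolic stability, read by LC-MS; a higher number here means that the compound lasts longer, a lower number that the compound disappears faster:
- compound 1 `NCc1ccc(C(=O)Nc2ccncc2F)cc1-c1cccc(NC(=O)c2cccc(C(=O)O)c2)c1`: > 2 h, a limit
- compound 2 `CCCCOC(=O)c1cccc(NC(=O)c2cccc(-c3cc(C(=O)Nc4ccncc4F)ccc3CN)c2)c1`: < 0.0834 h, a limit
- compound 3 `NCc1ccc(C(=O)Nc2ccncc2F)cc1-c1cccc(C(=O)Nc2ccc(CC(=O)O)cc2)c1`: > 2 h, a limit

All three results are limits, not numbers. Compound 3 stands at the limit of > 2 h in this assay, at which 2 of the 3 values shown sit. Compound 2, the only one without a free carboxy group, stands at the limit of < 0.0834 h in this assay, at which 1 of the 3 values shown sits.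

Compound 4 `NCc1ccc(C(=O)Nc2ccncc2F)cc1-c1cccc(C(=O)Nc2cccc(C(=O)O)c2F)c1` differs from compound 3 in one group: 3-carboxy-2-fluorophenyl in place of 4-(carboxymethyl)phenyl on an amide-type nitrogen. Compound 4 keeps a free carboxy group. Compound 3 also carries one and gives > 2 h, a limit. Compound 1 also carries one and gives > 2 h, a limit.

In this assay, no change beyond the scatter is expected, and the estimated step is a step that the limit leaves unreadable from compound 3 to compound 4. For compound 4 the expected value is 2.5 h, with an estimated range of 1 h to 5 h.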

Compound 4, half-life: > 2 h
Compound 4 ended at the assay's limit; the forecaster's own chance of this, stated with the estimate: 85%; the middle value is on the limit's open side.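

In this assay compound 4 gives > 2 h, a limit. Compound 3 gives > 2 h, also a limit. Among these compounds, no step between compound 3 and compound 4 can be read. The compounds shown leave open whether 3-carboxy-2-fluorophenyl and 4-(carboxymethyl)phenyl differ at all in half-life.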